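A Third Hydroxyl Side Chain on the Shared Core

The compounds below may be only part of what the source reports. "The series", "measured", "known", "first", "only" and "open" are said of these compounds alone.

Compound 2 `CC(C)(O)c1cn(CCNc2nonc2/C(=N/O)Nc2ccc(F)c(Br)c2)nn1` and compound 1 `OCCCc1cn(CCNc2nonc2/C(=N/O)Nc2ccc(F)c(Br)c2)nn1` share one core and differ only in the group on the five-membered aromatic ring. In an assay on isolated protein for inhibition of Indoleamine 2,3-dioxygenase 2 (Homo sapiens) (a lower number here means a stronger inhibitor, a higher number a weaker inhibitor), compound 1 gives 958 nM, and compound 2 gives 726 nM. Compound 2 has the lower of the two numbers, yet the step of a 1.3-fold lower number from compound 1 to compound 2 (0.12 log units; within the scatter) lies within the scatter, so the two compounds cannot be told apart. Compound 3 `OCCOCc1cn(CCNc2nonc2/C(=N/O)Nc2ccc(F)c(Br)c2)nn1` has not yet been measured; it carries (2-hydroxyethoxy)methyl in place of 1-hydroxy-1-methylethyl on an aromatic carbon. For the measured compounds named here, the only measured step, from compound 1 to compound 2, likewise exchanged one hydroxyl-bearing side chain on that carbon for another and changed little, so a step of similar size, or none beyond the scatter, is expected for a 1.1-fold higher number from compound 2 to compound 3 (0.04 log units; within the scatter). Compound 3 is therefore expected to give about 800 nM in this assay, with a range from 400 nM to 1600 nM.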

Compound 3, half-maximal inhibitory concentration: 144 nM
Compound 3: middle estimate off by 5.6-fold (0.74 log units), on the high side; the measured number lies below the stated range.
By their numbers in this assay, from the lowest: compound 3; then compounds 2 and 1 (each within the scatter of the next).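

In this assay, this position on the five-membered aromatic ring turns out to be sensitive to the side chain after all: (2-hydroxyethoxy)methyl in place of 1-hydroxy-1-methylethyl gives a 5.0-fold lower number from compound 2 to compound 3 (0.70 log units; beyond the scatter), although the earlier exchange of one hydroxyl-bearing chain for another stayed within the scatter. The change of 2-hydroxyethyl to 2-hydroxyethoxy on the chain points the same way, with a 6.7-fold lower number from compound 1 to compound 3 (0.82 log units; beyond the scatter). A hydroxyl alone therefore does not set the number, since all three compounds carry one and only compound 3 stands apart, with an ether oxygen in its chain.

Nothing available here explains why this chain gives the lower number. Still open, on these data alone, is whether the ether oxygen, the chain length or the end hydroxyl matters most, which a longer all-carbon chain, or an amine or carboxylic acid in place of the hydroxyl, could help separate.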